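Cyanoazetidine Ethers Against Acid Amidase: A Trifluoromethyl Step

A few compounds are considered here, and "the series" means these few. Any claim that something is new, unique, unknown or untested is made for them only; others in the source may bear on it.

Compound 1 `N#CN1CC(OCc2ccc(-c3ccccc3)cc2)C1`: 2.8 nM
Compound 2 `N#CN1CC(OCc2ccc(-c3cccc(OCc4ccccc4)c3)cc2)C1`: 1.4 nM

In an assay on isolated protein for inhibition of N-acylethanolamine-hydrolyzing acid amidase (Homo sapiens), read by fluorescence, with a stated time of 90 min (a lower number here means a stronger inhibitor, a higher number a weaker inhibitor), compound 1 gives 2.8 nM, the higher of the two numbers measured, though compound 2 at 1.4 nM lies within the scatter of it. For the measured compounds named here, the single measured step, a 2.0-fold lower number from compound 1 to compound 2 (0.30 log units; within the scatter), is small. Compound 3 `N#CN1CC(OCc2ccc(-c3ccc(C(F)(F)F)cc3)cc2)C1` differs from compound 1 by trifluoromethyl in place of hydrogen on an aromatic carbon. Going by the values given here, no measured step touches this position, and the one step known shows a ring substituent leaving the number little changed, so nothing beyond the scatter is expected here. Compound 3 is therefore estimated to give 3 nM in this assay, between 1 nM and 10 nM. That estimate means a 1.1-fold higher number from compound 1 to compound 3 (0.03 log units; within the scatter), expected to remain within the scatter.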

Compound 3, half-maximal inhibitory concentration: 1.6 nM
Estimate against measurement, compound 3: 1.9-fold (0.27 log units) above, and the stated range covers the measured number.
By their numbers in this assay, from the lowest: compounds 2, 3 and 1 (each within the scatter of the next).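

Trifluoromethyl on an aromatic carbon, para to a large group, is the only change shown at this position, and in this assay it gives a 1.8-fold lower number from compound 1 to compound 3 (0.24 log units; within the scatter) with all four of its heavy atoms in place of a single hydrogen. The position therefore accepts this larger group with the number staying within the scatter. Nothing available bears on why this is so. From the compounds shown here alone, whether an amine or a carboxylic acid at the same position would also leave the number within the scatter remains open.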